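This account rests on a few compounds, and the source may have more. Where it says the series, first, only, none or still open, it means among the compounds named here.

In a functional assay on RAW264.7 cells (Mus musculus) for inhibition, read by Griess assay, with stated times of 2 h and 24 h (on this read-out lower numbers stand for stronger inhibition and higher numbers for weaker inhibition), the three measured compounds stand as follows:
compound 1 `COc1ccc([C@@H]2C/C(=N\O)c3c(O)cc(OCc4cn(Cc5ccccc5C)nn4)cc3O2)cc1O`: 18000 nM
compound 2 `CCCCn1cc(COc2cc(O)c3c(c2)O[C@H](c2ccc(OC)c(O)c2)C/C3=N\O)nn1`: 8900 nM
compound 3 `COc1ccc([C@@H]2CC(=O)c3c(O)cc(OCc4cn(Cc5ccccc5Cl)nn4)cc3O2)cc1O`: 6140 nM

Compound 3 gives the lowest number of the three; its gap to compound 2 is within the scatter, while compound 1 stands clearly higher. Compound 4 `COc1ccc([C@@H]2CC(=O)c3c(O)cc(OCc4cn(C5CCCCC5)nn4)cc3O2)cc1O` has not yet been measured. It differs from compound 3 in one place: cyclohexyl in place of 2-chlorobenzyl on an aromatic nitrogen. Among the compounds with values here, the only measured step that resembles this exchange is a 2.0-fold lower number from compound 1 to compound 2 (0.31 log units; beyond the scatter), where propyl replaced 2-methylphenyl, a modest step. A similar modest lowering, or no step beyond the scatter, is therefore expected, as a 1.4-fold lower number from compound 3 to compound 4 (0.13 log units; within the scatter). For compound 4 in this assay the estimated value is 4500 nM, with a range from 1800 nM to 14000 nM.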

Compound 4, half-maximal inhibitory concentration: 15600 nM
The estimate for compound 4 lay 3.5-fold (0.54 log units) below the measured number; the whole stated range lies below it.
By their numbers in this assay, from the lowest: compounds 3, 2, 4 and 1 (each within the scatter of the next, the first and the last beyond it).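

In this assay, the group on this aromatic nitrogen cannot be exchanged freely: cyclohexyl in place of 2-chlorobenzyl gives a 2.5-fold higher number from compound 3 to compound 4 (0.40 log units; beyond the scatter) and so weakens inhibition beyond the scatter. The earlier exchange of an aromatic ring for propyl gave a 2.0-fold lower number from compound 1 to compound 2 (0.31 log units; beyond the scatter) in the opposite direction, so replacing an aromatic ring does not always move the number the same way. Nothing shown here explains this difference.

Still open, going by these compounds, is how a plain benzyl, a longer chain such as hexyl, or a group carrying an amine or a carboxylic acid would behave at this nitrogen.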